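This account rests on a few compounds, and the source may have more. Where it says the series, first, only, none or still open, it means among the compounds named here.

The measured compounds, with their values in a functional assay (trachea) with Cavia porcellus as the target; a higher number here means a weaker inhibitor, a lower number a stronger inhibitor:
compound 1 `CCCn1nc(-c2cccnc2)c2ccccc2c1=O` gives 3160 nM
compound 2 `CC(C)n1nc(-c2cccnc2)c2ccccc2c1=O` gives 3090 nM
compound 3 `O=c1c2ccccc2c(-c2cccnc2)nn1Cc1cccc(Cl)c1` gives 4170 nM

Compound 1 sits close to both of the others: the step of a 1.0-fold lower number from compound 1 to compound 2 (0.01 log units; within the scatter) and the step of a 1.3-fold higher number from compound 1 to compound 3 (0.12 log units; within the scatter) are each within the scatter, and so is a 1.3-fold higher number from compound 2 to compound 3 (0.13 log units; within the scatter). The three numbers therefore cannot be told apart by repeated measurement.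

The unmeasured compound 4 `O=c1c2ccccc2c(-c2cccnc2)nn1CCO` differs from compound 1 in one place: hydroxy in place of methyl on a saturated chain carbon, two bonds along the chain from an aromatic nitrogen. Within the data shown here, none of the measured steps introduces a hydroxy group onto this chain, so there is no direct precedent for it. What the measured steps do show is that swapping the group on the aromatic nitrogen, propyl for isopropyl or for 3-chlorobenzyl, leaves this assay essentially unchanged, each of those steps falling within the scatter. On that basis the expected step of a 1.1-fold higher number from compound 1 to compound 4 (0.04 log units; within the scatter) is small and in no particular direction, though the new hydroxy group carries more uncertainty than the earlier swaps did. Compound 4 is therefore estimated at 3500 nM, with a range from 1500 nM to 8000 nM.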

Compound 4, half-maximal inhibitory concentration: 4570 nM
Beside the measured number, compound 4's estimate is 1.3-fold (0.12 log units) below it; the measured number falls inside the stated range.
By their numbers in this assay, from the lowest: compounds 2, 1, 3 and 4 (each within the scatter of the next).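

Replacing the end methyl of the propyl chain with hydroxy adds a hydrogen-bond donor and acceptor that the earlier side groups lack, yet in this assay this gives a 1.4-fold higher number from compound 1 to compound 4 (0.16 log units; within the scatter). The same holds against the other two groups, with a 1.1-fold higher number from compound 3 to compound 4 (0.04 log units; within the scatter) and a 1.5-fold higher number from compound 2 to compound 4 (0.17 log units; within the scatter), so the four compounds cannot be told apart, and the insensitivity seen among straight-chain, branched and 3-chlorobenzyl groups on the aromatic nitrogen now extends to a 2-hydroxyethyl group. Among these compounds, no information at hand accounts for this flat result, so the data show only that the numbers match, not what lies behind them.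

The compounds shown leave open whether a different kind of group on the aromatic nitrogen, such as a chain ending in an amine or a carboxylic acid, or a longer chain carrying the hydroxy group, would move the number in this assay beyond the scatter. Since all four compounds share one core, they also leave open how much changes to that core would matter.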